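Chloro in Place of Bromo: Expected Cytotoxicity of Compound 4

The compounds below may be only part of what the source reports. "The series", "measured", "known", "first", "only" and "open" are said of these compounds alone.

Measured so far:
compound 1 `N#CCC(=O)N/N=C1\C(=O)Nc2ccc(S(=O)(=O)N3CCOCC3)cc21` — 302000 nM
compound 2 `O=C1Nc2ccc(S(=O)(=O)N3CCOCC3)cc2/C1=N/c1ccc(Br)cc1` — 372000 nM
compound 3 `CC(=O)N/N=C1\C(=O)Nc2ccc(S(=O)(=O)N3CCOCC3)cc21` — 325000 nM

All three share one core and were tested in an ADME assay on WI-38 cells (Homo sapiens) for cytotoxicity, read by sulforhodamine B assay, with a stated time of 24 h; on this read-out lower numbers stand for stronger inhibition and higher numbers for weaker inhibition. Compound 2 gives 372000 nM. Its nearest neighbour is compound 3, as a 1.1-fold lower number from compound 2 to compound 3 (0.06 log units; within the scatter) shows, and the step of a 1.2-fold higher number from compound 1 to compound 2 (0.09 log units; within the scatter) is likewise within the scatter, so the three numbers sit together and none stands apart.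

Compound 4 `O=C1Nc2ccc(S(=O)(=O)N3CCOCC3)cc2/C1=N/c1ccc(Cl)cc1` is not yet measured. It differs from compound 2 by a single substitution: chloro in place of bromo on an aromatic carbon. Within the data shown here, no measured step exchanges one halogen for another, so the only guidance is indirect. The steps of a 1.2-fold higher number from compound 1 to compound 2 (0.09 log units; within the scatter), a 1.1-fold higher number from compound 1 to compound 3 (0.03 log units; within the scatter) and a 1.1-fold lower number from compound 2 to compound 3 (0.06 log units; within the scatter) all involve larger rearrangements on the double-bonded nitrogen than this one, and each stayed within the scatter. A change as small as chloro for bromo is therefore expected to move this assay by no more than the scatter, in no preferred direction.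

On that basis compound 4 is expected to give about 370000 nM, between 200000 nM and 680000 nM, an estimated step of a 1.0-fold lower number from compound 2 to compound 4 (0.00 log units; within the scatter) from compound 2.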

Compound 4, half-maximal inhibitory concentration: 468000 nM
For compound 4 the middle estimate is 1.3-fold (0.10 log units) below the measured one; measured number inside the range.
By their numbers in this assay, from the lowest: compounds 1, 3, 2 and 4 (each within the scatter of the next).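

Among these compounds, this is the first direct exchange of one halogen for another at this position: in this assay, 4-chlorophenyl in place of 4-bromophenyl gives a 1.3-fold higher number from compound 2 to compound 4 (0.10 log units; within the scatter), so this swap does not separate the two compounds. The larger exchanges on the double-bonded nitrogen, which put 4-chlorophenyl in place of acetamido (a 1.4-fold higher number from compound 3 to compound 4 (0.16 log units; within the scatter)) and in place of ((cyanomethyl)carbonyl)amino (a 1.5-fold higher number from compound 1 to compound 4 (0.19 log units; within the scatter)), also stay within the scatter, so the new compound joins the other three as one tight group, and even the widest gap among the four does not pull any of them apart. Nothing available on these compounds offers an explanation for how closely their numbers agree.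

The compounds shown speak only to the group on the double-bonded nitrogen and to the halogen on its phenyl ring, so they leave open whether an amine or a carboxylic acid in place of the chloro would stand apart from this group. They also leave open whether a longer chain in place of the acetamido methyl, or a change elsewhere on the shared core, would move the number beyond the scatter.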